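Swapping the Methoxyphenyl Sulfonamide for a Chlorophenyl Analogue

The compounds below may be only part of what the source reports. "The series", "measured", "known", "first", "only" and "open" are said of these compounds alone.

Three compounds on a shared core have been compared in an assay on brain for displacement of a labelled ligand from D(3) dopamine receptor (Rattus norvegicus); on this read-out higher numbers stand for weaker inhibition and lower numbers for stronger inhibition. Compound 1 `CCCN(CC[C@H]1CC[C@H](NC(=O)/C=C/c2ccc(Cl)cc2)CC1)[C@H]1CCc2nc(N)sc2C1` gives 2.5 nM. Compound 2 `CCCN(CC[C@H]1CC[C@H](NS(=O)(=O)c2ccc(-c3ccccc3)cc2)CC1)[C@H]1CCc2nc(N)sc2C1` gives 41 nM. Compound 3 `CCCN(CC[C@H]1CC[C@H](NS(=O)(=O)c2ccc(OC)cc2)CC1)[C@H]1CCc2nc(N)sc2C1` gives 0.78 nM, the lowest of the three numbers: compound 1 lies nearest and compound 2 furthest, as the steps of a 3.2-fold lower number from compound 1 to compound 3 (0.51 log units; beyond the scatter) and a 53-fold lower number from compound 2 to compound 3 (1.72 log units; beyond the scatter) show. Compound 4 `CCCN(CC[C@H]1CC[C@H](NS(=O)(=O)c2ccccc2Cl)CC1)[C@H]1CCc2nc(N)sc2C1` has not yet been measured in this assay. It differs from compound 3 in one place: 2-chlorophenyl in place of 4-methoxyphenyl on a sulfonyl sulfur. For the measured compounds named here, of the measured steps, the one from compound 2 to compound 3 also changed the aryl group on the sulfonyl sulfur and was large, a 53-fold lower number from compound 2 to compound 3 (1.72 log units; beyond the scatter); the step of a 3.2-fold lower number from compound 1 to compound 3 (0.51 log units; beyond the scatter) replaced the whole substituent on the amine nitrogen and was modest. Neither step tests a 2-chlorophenyl group, so the change is read as likely to move the number upward by a moderate amount, with considerable uncertainty. Compound 4 is therefore estimated at 5 nM, between 1.5 nM and 20 nM, an expected step of a 6.4-fold higher number from compound 3 to compound 4 (0.81 log units; beyond the scatter).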

Compound 4, inhibition constant: 0.68 nM
For compound 4 the middle estimate is 7.4-fold (0.87 log units) above the measured one; measured number below the stated range.
By their numbers in this assay, from the lowest: compounds 4 and 3 (each within the scatter of the next); then compound 1; then compound 2.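

In this assay, the step of a 1.1-fold lower number from compound 3 to compound 4 (0.06 log units; within the scatter) shows that on the sulfonyl sulfur a ring carrying chlorine can take the place of one carrying methoxy with no change beyond the scatter, so the two aryl groups cannot be told apart on this read-out. For the compounds shown here, the step of a 60-fold lower number from compound 2 to compound 4 (1.78 log units; beyond the scatter) is large, as the earlier one from the 4-phenylphenyl compound was, which leaves 4-phenylphenyl as the one aryl group of the three on this sulfur that stands apart. The step of a 3.7-fold lower number from compound 1 to compound 4 (0.57 log units; beyond the scatter) is modest, so a second sulfonamide now also differs from the (2-(4-chlorophenyl)ethenyl)carbonyl compound in the same direction.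

Nothing given here explains why the two aryl groups read alike. Open too, as far as these compounds go, is how the number would respond to an amine or a carboxylic acid on this aryl ring, or to a plain methyl on the sulfonyl sulfur in place of the ring.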